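The source may report more compounds than this note shows. Statements on the series, on what has been measured and on what is new or still open speak of the compounds shown alone.

Compound 1 `CCCn1c(N2CCN(C)CC2)nc2ccccc21` gives 380 nM in a functional assay on ileum for inhibition of histamine H1 receptor (Cavia porcellus); on this read-out higher numbers stand for weaker inhibition and lower numbers for stronger inhibition.
Compound 2 `CCNCCn1c(N2CCN(C)CC2)nc2ccccc21` gives 290 nM in this assay.

Compound 2 holds the lowest of the two numbers, though this carries little weight, since the step from compound 1 to compound 2, a 1.3-fold lower number from compound 1 to compound 2 (0.12 log units; within the scatter), lies within the scatter. Compound 3 `CCCCOCCn1c(N2CCN(C)CC2)nc2ccccc21` differs from compound 2 by butoxy in place of ethylamino on a saturated chain carbon, two bonds along the chain from an aromatic nitrogen. Among the compounds with values here, the only measured step that bears on this change is that one, and it was within the scatter, so compound 3 is expected to sit close to compound 2 with no clear shift in either direction. The estimate for compound 3 in this assay is 400 nM, between 150 nM and 1200 nM, an expected step of a 1.4-fold higher number from compound 2 to compound 3 (0.14 log units; within the scatter).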

Compound 3, half-maximal inhibitory concentration: 38 nM
Compound 3: the middle estimate sits 11-fold (1.02 log units) above what was measured, and the stated range ends above it.
By their numbers in this assay, from the lowest: compound 3; then compounds 2 and 1 (each within the scatter of the next).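

At this saturated chain carbon, two bonds along the chain from an aromatic nitrogen, the choice of group clearly matters in this assay. Butoxy in place of ethylamino gives a 7.6-fold lower number from compound 2 to compound 3 (0.88 log units; beyond the scatter) and butoxy in place of methyl gives a 10-fold lower number from compound 1 to compound 3 (1.00 log units; beyond the scatter), whereas ethylamino in place of methyl had shown no change beyond the scatter. No measured evidence bears on the reason for this shift.

Butoxy differs from ethylamino in both chain length and heteroatom, so the two remain unseparated. An ethoxy or a butylamino group at this place would tell them apart.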